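Compound 4 in the MT4 Cell Toxicity Series

The source may hold more compounds than are shown below. What is called first, only, known or untested is meant among the compounds shown, and "the series" means these compounds.

Values in a toxicity assay on MT4 cells (Homo sapiens) for cytotoxicity, read by MTT assay, with a stated time of 5 days; a higher number here means that more compound is tolerated, a lower number that less compound is tolerated:
- Compound 1 `Cc1cc(-c2ccnc3ccccc23)cc(C)c1Nc1ccnc(Nc2ccc(C#N)cc2)n1`: 3500 nM
- Compound 2 `Cc1ccc(-c2cc(C)c(Nc3ccnc(Nc4ccc(C#N)cc4)n3)c(C)c2)s1`: 28000 nM
- Compound 3 `Cc1cc(-c2cc(C)c(Nc3ccnc(Nc4ccc(C#N)cc4)n3)c(C)c2)cc(C)n1`: 2300 nM

Compound 3 stands at the low end of these numbers, although the measured gap is a 1.5-fold lower number from compound 1 to compound 3 (0.18 log units; within the scatter). It lies well apart from the thiophene-bearing compound, with a 12-fold lower number from compound 2 to compound 3 (1.09 log units; beyond the scatter).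

Compound 4 `Cc1cc(-c2cnc(C#N)nc2)cc(C)c1Nc1ccnc(Nc2ccc(C#N)cc2)n1` carries 2-cyanopyrimidin-5-yl in place of 2,6-dimethylpyridin-4-yl on an aromatic carbon. Within the data shown here, no measured compound contains the entering group, so only the swaps at this same place bear on the change. Those swaps gave a 1.5-fold lower number from compound 1 to compound 3 (0.18 log units; within the scatter) and an 8.0-fold higher number from compound 1 to compound 2 (0.90 log units; beyond the scatter), which shows that this place can produce either a step within the scatter or a clearly larger one.

The expected step in this assay is a 2.0-fold higher number from compound 3 to compound 4 (0.29 log units; within the scatter), with no shift beyond the scatter anticipated. The upper range stays wide, as compound 2 reached 28000 nM. Compound 4 is estimated at 4500 nM, with an expected range from 1500 nM to 20000 nM.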

Compound 4, half-maximal cytotoxic concentration: 3100 nM
The estimate for compound 4 lay 1.5-fold (0.16 log units) above the measured number, and the stated range covers the measured number.
By their numbers in this assay, from the lowest: compounds 3, 4 and 1 (each within the scatter of the next); then compound 2.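

In this assay, replacing 2,6-dimethylpyridin-4-yl with 2-cyanopyrimidin-5-yl gives a 1.3-fold higher number from compound 3 to compound 4 (0.13 log units; within the scatter) and the comparison with the quinolin-4-yl group gives a 1.1-fold lower number from compound 1 to compound 4 (0.05 log units; within the scatter) so this place tolerated a ring with 2 hetero atoms and a nitrile without a step beyond the scatter. Against the 5-methylthiophen-2-yl group, the same entering group gives a 9.0-fold lower number from compound 2 to compound 4 (0.96 log units; beyond the scatter) and this leaves compound 2 as the only one of the four compounds set apart from the others. The new result therefore extends the group of compounds with closely matching numbers, and 5-methylthiophen-2-yl remains the exception.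

On these data alone, whether an unsubstituted thiophen-2-yl or a morpholine at this place would follow compound 2 or the other three remains open. Nothing given here explains the separate position of compound 2.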